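Methylating the phenolic hydroxy of compound 1

A few compounds are considered here, and "the series" means these few. Any claim that something is new, unique, unknown or untested is made for them only; others in the source may bear on it.

Of the compounds shown here, two have so far been tested in a functional assay on cells (Cancer cell lines, Homo sapiens) for cytotoxicity, with a stated time of 48 h; on this read-out higher numbers stand for weaker inhibition of growth and lower numbers for stronger inhibition of growth. Compound 1 `COc1cc2c(/C=C3/C(=O)Nc4ccc(O)cc43)c(Cl)n(Cc3cc(OC)c(OC)c(OC)c3)c2cc1C` gives 34700 nM in this assay. Compound 2 `COc1ccc2c(c1)/C(=C\c1c(Cl)n(C/C=C/c3ccccc3)c3ccccc13)C(=O)N2` gives 36300 nM in this assay. Compound 1 has the lower of the two numbers, but the gap to compound 2 lies within the usual scatter, so no order between them can be drawn. Compound 3 `COc1ccc2c(c1)/C(=C\c1c(Cl)n(Cc3cc(OC)c(OC)c(OC)c3)c3cc(C)c(OC)cc13)C(=O)N2` differs from compound 1 by methyl in place of hydrogen on an oxygen on an aromatic ring. Within the data shown here, no measured pair shows the effect of this change, so the direction of the step is unknown from the data. Given that compound 1 sits at 34700 nM, the step is expected to be small, a 1.0-fold higher number from compound 1 to compound 3 (0.00 log units; within the scatter), and most likely not beyond the scatter in either direction. Compound 3 is therefore estimated at 35000 nM in this assay, with a range from 15000 nM to 80000 nM.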

Compound 3, concentration for total growth inhibition: 57500 nM
Compound 3: the middle estimate sits 1.6-fold (0.22 log units) below what was measured, and the stated range covers the measured number.
By their numbers in this assay, from the lowest: compounds 1, 2 and 3 (each within the scatter of the next).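

In this assay, among these compounds, the change from hydroxy to methoxy on the aromatic ring gives a 1.7-fold higher number from compound 1 to compound 3 (0.22 log units; within the scatter) and so provides the first reading for this position. Methyl in place of the hydrogen on this oxygen leaves the two numbers within the scatter of each other, which shows that, on the core of compound 1, the free hydroxy is not needed to retain the level of growth inhibition seen in this pair. The data shown offer no measured explanation for this step. Going by these compounds, it remains open whether a larger group on this oxygen, such as benzyl, or an amine or a carboxylic acid in place of the hydroxy, would move the number beyond the scatter. On these data alone, whether methyl on this oxygen behaves the same way with a different group elsewhere on the core also remains open.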